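Adding Chloro to Compound 2: An Expected Toxicity Reading

The source may report more compounds than this note shows. Statements on the series, on what has been measured and on what is new or still open speak of the compounds shown alone.

Among the measured compounds shown here, compound 2 `COc1cc(-c2nn(-c3cccc(NC(=O)Nc4cccc(C(F)(F)F)c4)c3)cc2-c2ccncc2)ccc1Cl` gives the only number in a functional assay on SNB-75 cells (Homo sapiens) for inhibition, read by sulforhodamine B assay, with a stated time of 48 h (on this read-out higher numbers stand for lower toxicity in this test and lower numbers for higher toxicity in this test), namely 50000 nM. Compound 1 `O=C(Nc1cccc(-n2cc(-c3ccncc3)c(-c3ccc(Cl)c(O)c3)n2)c1)Nc1cccc(C(F)(F)F)c1` reaches only a limit of > 32500 nM in this assay. The step from compound 1 to compound 2, methyl in place of hydrogen on an oxygen on an aromatic ring, is a step that the limit leaves unreadable from compound 1 to compound 2 because of the limit of > 32500 nM in this assay, at which 1 of the 2 values shown sits. Compound 3 `COc1cc(-c2nn(-c3cccc(NC(=O)Nc4ccc(Cl)c(C(F)(F)F)c4)c3)cc2-c2ccncc2)ccc1Cl` differs from compound 2 by chloro in place of hydrogen on an aromatic carbon. For the measured compounds named here, no measured step touches the ring that carries the trifluoromethyl group, and the one measured step is unreadable, so no direction can be drawn from it; compound 2 sits at the weakly toxic end of what the assay reports. The expected step from compound 2 to compound 3 in this assay is therefore a 1.1-fold lower number from compound 2 to compound 3 (0.05 log units; within the scatter), nothing beyond the scatter. Compound 3 is thus estimated at 45000 nM, within 15000 nM to 100000 nM, with a fair chance that only a limit is reported.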

Compound 3, concentration lethal to 50% of the cells: > 32500 nM
Compound 3: no number, only a limit; the forecaster's own chance of this, stated with the estimate: 45%; the middle value lies beyond the limit too.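

No new step can be read, because compound 3, like compound 1, gives only a limit in this assay; the step from compound 2 to compound 3 stays unreadable: the limit of > 32500 nM in this assay, at which 2 of the 3 values shown sit. The compounds shown leave open whether chloro in place of hydrogen changes the lethal concentration at all.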